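The source may report more compounds than this note shows. Statements on the series, on what has been measured and on what is new or still open speak of the compounds shown alone.

Compound 1 `O=C(Nc1cccnc1)NC1CCN(c2ncc(C(F)(F)F)cc2Cl)CC1` is tested in an assay on membranes from brain for binding affinity to Lysophosphatidylserine lipase ABHD12 (Mus musculus), read by fluorescence, with a stated time of 20 min, tested at 2 uM (on this read-out lower numbers stand for a weaker effect and higher numbers for a stronger effect at the one concentration tested), where compound 1 gives 1%. Compound 2 `FC(F)(F)c1cnc(N2CCC(NC(=S)Nc3cccnc3)C2)c(Cl)c1` gives 1% in this assay, level with compound 1 at the digits shown, and together they are the lowest of the three numbers. Compound 3 `FC(F)(F)c1cnc(NCCCCCCNC(=S)Nc2cccnc2)c(Cl)c1` gives 22%, a number that stands higher than compound 1 by more than the usual scatter. Compound 4 `FC(F)(F)c1cnc(N2CCC(NC(=S)Nc3ccccc3)CC2)c(Cl)c1` has not yet been measured in this assay. It differs from compound 1 on an amine nitrogen whose other neighbour is a saturated ring carbon: a group of 9 heavy atoms (7 carbon, 1 nitrogen, 1 sulfur; one six-membered aromatic ring of carbon only) in place of a group of 9 heavy atoms (6 carbon, 2 nitrogen, 1 oxygen; one six-membered aromatic ring with 1 hetero atom), on an amine nitrogen. Among the measured compounds shown here, no step between two measured compounds corresponds to this change, so its direction cannot be read from a measured pair. Compound 2 carries sulfur in the corresponding group and gives 1%, while compound 3 likewise carries sulfur there and gives 22%. The change is therefore expected to bring only a small step, a number 5 percentage points higher from compound 1 to compound 4 (within the scatter), not beyond the scatter with confidence. Compound 4 is expected to give 6%, within a range from 0% to 20%.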

Compound 4, a percentage reported as inhibition, at one concentration (the size of the read-out at that concentration, not a potency): 66%
Compound 4: the middle estimate sits 60 percentage points below what was measured, outside the stated range (above it).
By their numbers in this assay, from the lowest: compounds 1 and 2 (each within the scatter of the next); then compound 3; then compound 4.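

On an amine nitrogen whose other neighbour is a saturated ring carbon, replacing the (pyridin-3-yl)carbamoyl group with a group carrying sulfur and a six-membered aromatic ring of carbon only gives a number 65 percentage points higher from compound 1 to compound 4 (beyond the scatter) in this assay, with the same count of heavy atoms on both sides. Among the compounds shown here, the earlier compounds offered no measured step between compounds differing in one place, so this is the first indication that the read-out responds strongly to a change at this position. No measurement at hand gives a reason for this step.

The change exchanges oxygen for sulfur and the ring nitrogen for carbon together, so the compounds shown do not tell which of the two carries the step. They also leave open how a chlorine or a methoxy group on the carbon-only ring would affect the read-out.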